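This account rests on a few compounds, and the source may have more. Where it says the series, first, only, none or still open, it means among the compounds named here.

Measured so far:
- Compound 1, `C[C@H](NC(=O)c1cc(C2CC2)nn1C)c1nc(-c2ccccc2)no1`: 11400 nM
- Compound 2, `Cc1cccc(-c2noc([C@H](C)NC(=O)c3cc(C(F)(F)F)nn3C)n2)n1`: > 30000 nM (a limit of the assay, not a number)

In an assay on T-REx-293 cells for inhibition of potassium channel subfamily T member 1 (Homo sapiens), read by patch clamp (a higher number here means a weaker inhibitor, a lower number a stronger inhibitor), compound 1 gives 11400 nM. Compound 2 stands at the limit of > 30000 nM in this assay, at which 1 of the 2 values shown sits, so for compound 2 only a limit is known and no number. Compound 3, `C[C@H](NC(=O)c1cc(C(F)(F)F)nn1C)c1nc(-c2ccccn2)no1`, has not been measured. It differs from compound 2 by hydrogen in place of methyl on an aromatic carbon, so the 6-methylpyridin-2-yl group becomes pyridin-2-yl. Among the compounds with values here, no measured pair shows this change, so the size of the step is unknown; removing one carbon from a group of this kind is expected to shift the result little, in no clear direction, and most likely within the scatter. On that basis compound 3 is expected to show about 35000 nM, with a range from 10000 nM to 100000 nM. The step this estimate implies, a step that the limit leaves unreadable from compound 2 to compound 3, is expected to stay within the scatter, and the result for compound 3 may well again be only a limit.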

Compound 3, half-maximal inhibitory concentration: > 30000 nM
Compound 3 gave a limit, no number; the forecaster's own chance of this, stated with the estimate: 60%; the middle value lies beyond the limit too.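

Compound 2 and compound 3 each end at a limit of the assay, not a number, so no step can be read for the change from 6-methylpyridin-2-yl to pyridin-2-yl: the limit of > 30000 nM in this assay, at which 2 of the 3 values shown sit.
The compounds shown leave open whether this change alters inhibition at all.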